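Halogen-substituted phenyl variants on the shared core

The compounds below may be only part of what the source reports. "The series", "measured", "known", "first", "only" and "open" are said of these compounds alone.

Measured so far in a functional assay on cardiac atrium for agonist activity at histamine H2 receptor (Cavia porcellus); on this read-out lower numbers stand for smaller maximal responses and higher numbers for larger maximal responses:
compound 1 `N=C(NCCCc1c[nH]cn1)NCCC(c1ccc(F)cc1)c1ccccn1` gives 1
compound 2 `N=C(NCCCc1c[nH]cn1)NCCC(c1ccc(Br)cc1)c1ccccn1` gives 1
compound 3 `N=C(NCCCc1c[nH]cn1)NCCC(c1cccc(F)c1)c1ccccn1` gives 1

In this assay compound 3 stands level with compounds 1 and 2; the steps of no change at the digits printed from compound 1 to compound 3 (within the scatter) and no change at the digits printed from compound 2 to compound 3 (within the scatter) lie within the scatter. Compound 4 `N=C(NCCCc1c[nH]cn1)NCCC(c1ccc(Cl)c(Cl)c1)c1ccccn1` differs from compound 3 by 3,4-dichlorophenyl in place of 3-fluorophenyl on a saturated chain carbon bound to an aromatic carbon and a saturated chain carbon.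

Bearing on this change are no change at the digits printed from compound 1 to compound 2 (within the scatter), no change at the digits printed from compound 1 to compound 3 (within the scatter) and no change at the digits printed from compound 2 to compound 3 (within the scatter): every halogen exchange or shift of the halogen on the phenyl so far left the maximal response unmoved. Among the measured compounds shown here, a second chlorine enters here, which no measured pair covers, but nothing seen suggests a step beyond the scatter, so the expected step is no change at the digits printed from compound 3 to compound 4 (within the scatter). Compound 4 is estimated at 1, within 0.85 to 1.05.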

Compound 4, intrinsic activity: the largest response reached, as a fraction of the reference agonist's: 1
Beside the measured number, compound 4's estimate shows no gap at the digits printed, and the stated range covers the measured number.
By their numbers in this assay, from the lowest: compounds 1, 2, 3 and 4 (each within the scatter of the next).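

In this assay, two chlorines on the phenyl at this saturated chain carbon give no change at the digits printed from compound 3 to compound 4 (within the scatter), and the comparisons with the single-halogen compounds give no change at the digits printed from compound 2 to compound 4 (within the scatter) and also no change at the digits printed from compound 1 to compound 4 (within the scatter) here. Chlorine and a second halogen on the ring therefore join fluoro and bromo among the changes that leave this maximal response level. No supporting data account for this flat result.

As far as these compounds go, whether an unsubstituted phenyl, or a phenyl carrying an amine or a carboxylic acid, would stay level remains open. Potency is also left open, since only the maximal response is shown.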